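The source may hold more compounds than are shown below. What is called first, only, known or untested is meant among the compounds shown, and "the series" means these compounds.

Measured compounds:
compound 1 `C[C@@H](O)[C@H]1C(=O)N2C(C(=O)OCOC(=O)C(C)(C)C)=C(S[C@@H]3CN[C@H](C(=O)Nc4cccc(C(=O)O)c4)C3)[C@H](C)[C@H]12`; in a physicochemical assay for metabolic stability, read by LC-MS, in phosphate buffer, with a stated time of 3 h, at pH 7.4, tested at 50 uM (on this read-out higher numbers stand for a more stable compound and lower numbers for a less stable compound), compound 1 gives > 95%, which is a limit of the assay.
compound 2 `CCOC(=O)OCOC(=O)C1=C(S[C@@H]2CN[C@H](C(=O)Nc3cccc(C(=O)O)c3)C2)[C@H](C)[C@@H]2[C@@H]([C@@H](C)O)C(=O)N12`; in this assay compound 2 gives > 95%, likewise a limit of the assay.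

Within the data shown here, compound 1 stands at the upper limit of this assay, and the only other value shown sits at the same limit: the limit of > 95% in this assay, at which 2 of the 2 values shown sit. Among the measured compounds shown here, the one measured step, a step that the two limits leave unreadable from compound 1 to compound 2, is therefore not readable in size, and compound 1 cannot be ordered against compound 2 on these numbers.

Compound 3 `C[C@@H](O)[C@H]1C(=O)N2C(C(=O)OCOC(=O)C(C)(C)C)=C(S[C@@H]3CN[C@H](C(=O)Nc4cccc(C(=O)OCOC(=O)C(C)(C)C)c4)C3)[C@H](C)[C@H]12` differs from compound 1 by (((tert-butyl)carbonyl)oxy)methyl in place of hydrogen on an oxygen next to a carbonyl group. For the measured compounds named here, no measured step touches this oxygen; the step from compound 1 to compound 2 concerns a different position and is unreadable in any case. With compound 1 at the limit and no readable step to lean on, the expectation for compound 3 in this assay is a value close to the same limit, with the expected step of a number no higher from compound 1 to compound 3 (the limit leaves the size open) not beyond the scatter. Compound 3 is thus estimated at 95%, within the range 85% to 100%.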

Compound 3, percent of the compound remaining: > 95%
Compound 3 ended at the assay's limit; the forecaster's own chance of this, stated with the estimate: 70%; the middle value lies on the limit itself.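

In this assay compound 3 gives > 95%, which is a limit of the assay. No step can be read from compound 1 to compound 3, because the values shown share one limit: the limit of > 95% in this assay, at which 3 of the 3 values shown sit. The compounds shown leave open whether compound 1, compound 2 and compound 3 differ at all in this assay, and by how much.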